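Removing the (4-methylphenyl)sulfonyl group from compound 1

The source may report more compounds than this note shows. Statements on the series, on what has been measured and on what is new or still open speak of the compounds shown alone.

Measured so far:
- Compound 1 `Cc1ccc(S(=O)(=O)O[C@@H]2CO[C@H]3[C@@H]2OCc2nc4c(Br)c(C)c(Br)cc4n23)cc1`: 8940 nM
- Compound 2 `O[C@@H]1CO[C@H]2[C@@H]1OCc1nc3cc(F)c(F)cc3n12`: 512000 nM

The read-out here is an ADME assay on HEp-2 cells (Homo sapiens) for cytotoxicity, read by MTT assay, with a stated time of 60 h; on this read-out higher numbers stand for lower toxicity in this test and lower numbers for higher toxicity in this test. In this assay compound 1 gives 8940 nM, the lowest of the two numbers, and so the more toxic of the pair in this test. In this assay compound 2 gives 512000 nM, a far higher number, well beyond the scatter of the test.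

Compound 3 `Cc1c(Br)cc2c(nc3n2[C@H]2OC[C@@H](O)[C@H]2OC3)c1Br` is not yet measured. It differs from compound 1 in one place: hydrogen in place of (4-methylphenyl)sulfonyl on an oxygen on a saturated carbon. The (4-methylphenyl)sulfonyl group is a sizeable part of compound 1, and its loss leaves a bare hydroxyl on the core.

Within the data shown here, no measured pair shows this exact change, so the size of the step can only be guessed from the two numbers at hand. Compound 2 shows that a member of this set can reach a much higher number than compound 1, and the step expected from removing the large group is a rise of roughly an 11-fold higher number from compound 1 to compound 3 (1.05 log units; beyond the scatter). For compound 3 in this assay the estimate is 100000 nM, with a range from 20000 nM to 500000 nM.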

Compound 3, half-maximal cytotoxic concentration: 34300 nM
The estimate for compound 3 lay 2.9-fold (0.46 log units) above the measured number; the range from low to high includes it.
By their numbers in this assay, from the lowest: compound 1; then compound 3; then compound 2.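

In this assay, among these compounds, this pair gives the first direct reading of a change at this oxygen on a saturated carbon: replacing (4-methylphenyl)sulfonyl with hydrogen gives a modest step (a 3.8-fold higher number from compound 1 to compound 3 (0.58 log units; beyond the scatter)), though one that is beyond the usual scatter. On this read-out, a higher number stands for lower toxicity in the test, so the compound with the free hydroxyl is the less toxic of this pair, but this is one pair on one core and supports no general rule. Nothing among the data shown explains why the number rises with this change.

The compounds shown leave open whether the size of the whole (4-methylphenyl)sulfonyl group matters or only some part of it, such as its aromatic ring or its sulfur, and a methyl ether, an acetyl ester or an amine on the same carbon would help to separate these possibilities. They also leave open whether the same change would give a step of similar size on a core carrying other groups, since compound 2 differs from compound 1 and compound 3 in more than one place and offers no such comparison.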